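Purine Pairs and the Cost of Losing One Chloro

The source may hold more compounds than are shown below. What is called first, only, known or untested is meant among the compounds shown, and "the series" means these compounds.

The account concerns two pairs of purine-type compounds. Compound 3 `ClCc1ccccc1Cn1cnc2nc(Cl)nc(Cl)c21` and compound 2 `ClCc1ccccc1Cn1cnc2ncnc(Cl)c21` were both measured in a functional assay on HOP-92 cells (Homo sapiens) for cytotoxicity, read by sulforhodamine B assay, with a stated time of 48 h; on this read-out lower numbers stand for stronger inhibition of growth and higher numbers for weaker inhibition of growth. In this assay compound 3 gives 2810 nM, while compound 2 gives 12900 nM. The change between them is hydrogen in place of chloro on an aromatic carbon, and it made the step of a 4.6-fold higher number from compound 3 to compound 2 (0.66 log units; beyond the scatter).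

Compound 1 `ClCc1ccc(Cn2cnc3nc(Cl)nc(Cl)c32)cc1` carries the same atoms as compound 3, joined differently; the difference between the two cores is not broken down here. In this assay compound 1 gives "not determined" (no result reported), so no number is available for it.

Compound 4 `ClCc1ccc(Cn2cnc3ncnc(Cl)c32)cc1` has not yet been measured. It differs from compound 1 by hydrogen in place of chloro on an aromatic carbon, the same change that separates compound 3 from compound 2. Since compound 1 has no number, the earlier step cannot be applied to it directly, and the expectation for compound 4 rests instead on compound 2, which gives 12900 nM and shares the same substitution pattern on the core. Compound 4 is therefore expected to give about 13000 nM, with a plausible range from 4000 nM to 45000 nM.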

Compound 4, concentration for total growth inhibition: 2510 nM
Compound 4: middle estimate off by 5.2-fold (0.71 log units), on the high side; the measured number lies below the stated range.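

No new step can be read from this result: compound 4 differs from compound 1 in one place, but in this assay compound 1 gives "not determined" (no result reported). No supporting evidence bears on the value of compound 4. From the compounds shown here alone, what the chloro between two ring nitrogen atoms contributes in the core of compound 1 remains open.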